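The source may hold more compounds than are shown below. What is called first, only, known or untested is meant among the compounds shown, and "the series" means these compounds.

Compound 1 `CCCCCCCCNc1nc(SCc2ccc(C(F)(F)F)cc2)nc2ccccc12` carries an octyl chain on a nitrogen attached to the shared core, and in a functional assay on MDA-MB-231 cells (Homo sapiens) for cytotoxicity, read by MTT assay, with a stated time of 72 h (on this read-out higher numbers stand for weaker inhibition and lower numbers for stronger inhibition), compound 1 gives 22300 nM. Compound 2 `COc1ccccc1Nc1nc(SCc2ccc(C(F)(F)F)cc2)nc2ccccc12` has a 2-methoxyphenyl group on that nitrogen instead. In this assay compound 2 reaches only the limit of the assay, > 50000 nM, so no exact number exists for it. The step of an at least 2.2-fold higher number from compound 1 to compound 2 (0.35 log units; beyond the scatter) is thus known only as a bound because the limit of > 50000 nM in this assay, at which 1 of the 2 values shown sits, marks the ceiling of what the assay reports.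

Compound 3 `Cc1ccccc1Nc1nc(SCc2ccc(C(F)(F)F)cc2)nc2ccccc12` differs from compound 2 by methyl in place of methoxy on an aromatic carbon. Within the data shown here, none of the measured steps exchanges methoxy for methyl; the single step seen, from octyl to 2-methoxyphenyl, does not bear on this change. With compound 2 already sitting at the limit, the expected step that the limit leaves unreadable from compound 2 to compound 3 is none beyond the scatter, and a result reported again only as a limit is the most likely outcome. Compound 3 is therefore estimated at about 60000 nM, within a range from 20000 nM to 200000 nM.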

Compound 3, half-maximal inhibitory concentration: 27100 nM
Estimate against measurement, compound 3: 2.2-fold (0.35 log units) above, within the range that was stated.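

In this assay, the exchange of methoxy for methyl on this aromatic carbon gives an at least 1.8-fold lower number from compound 2 to compound 3 (0.26 log units; that floor lies within the scatter), so this small change turns a result without an exact number into a measured one, although the step's known floor does not by itself establish a real difference. The second comparison gives a 1.2-fold higher number from compound 1 to compound 3 (0.08 log units; within the scatter), which means that 2-methylphenyl and octyl on the nitrogen cannot be told apart here, and compound 3 therefore goes against any reading of the earlier step as a general loss on placing an aromatic ring at that nitrogen. The true size of the step to compound 3 stays unknown because compound 2 has only a limit, not a number: the limit of > 50000 nM in this assay, at which 1 of the 3 values shown sits.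

Going by these compounds, what a hydroxy group, a chlorine atom or an unsubstituted phenyl ring would give at this place on the ring stays open, so two ring substituents cannot define a trend. On these data alone, it is also open how a shorter chain, a longer chain or a chain ending in an amine on the nitrogen would compare with the octyl group of compound 1.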